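The compounds below may be only part of what the source reports. "The series", "measured", "known", "first", "only" and "open" are said of these compounds alone.

Measured in a functional assay on HepG2 cells (Homo sapiens) for cytotoxicity, read by MTT assay, with a stated time of 24 h; a higher number here means a weaker inhibitor, a lower number a stronger inhibitor:
- compound 1 `N#Cc1ccc(S(=O)(=O)N2C/C(=C\c3cccnc3)C(=O)/C(=C/c3ccccc3C(F)(F)F)C2)cc1`: 5060 nM
- compound 2 `Cc1ccc(S(=O)(=O)N2C/C(=C\c3ccncc3)C(=O)/C(=C/c3ccccc3C(F)(F)F)C2)cc1`: 4640 nM
- compound 3 `O=C1/C(=C/c2ccncc2)CN(S(=O)(=O)c2ccc(C(F)(F)F)cc2)C/C1=C\c1ccccc1C(F)(F)F`: 3240 nM

These three numbers lie within the usual scatter of repeat measurements, so they cannot be ranked. Compound 3, at 3240 nM, is within that scatter of both compound 1 and compound 2.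

The next compound to test is compound 4 `N#Cc1ccc(S(=O)(=O)N2C/C(=C\c3ccncc3)C(=O)/C(=C/c3ccccc3C(F)(F)F)C2)cc1`. It differs from compound 3 in one place, with cyano in place of trifluoromethyl on an aromatic carbon.

For the measured compounds named here, only one measured step involves a change at this same group, namely a 1.4-fold lower number from compound 2 to compound 3 (0.16 log units; within the scatter). There, trifluoromethyl replaced methyl, and the difference stayed within the scatter. That single step does not test a cyano group directly. Compound 1 does carry the 4-cyanophenyl group, but it also differs from compound 4 elsewhere in the structure. Compound 1, at 5060 nM, still falls within the scatter of compound 3. Neither observation points to a real shift in either direction in this assay.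

The expected change is small and within the scatter: a 1.2-fold higher number from compound 3 to compound 4 (0.09 log units; within the scatter). For compound 4 the estimated value is 4000 nM, with an expected range of 2200 nM to 7300 nM.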

Compound 4, half-maximal inhibitory concentration: 5920 nM
Compound 4: the middle estimate sits 1.5-fold (0.17 log units) below what was measured; the measured number falls inside the stated range.
By their numbers in this assay, from the lowest: compounds 3, 2, 1 and 4 (each within the scatter of the next).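

In this assay, the change from 4-(trifluoromethyl)phenyl to 4-cyanophenyl gives a 1.8-fold higher number from compound 3 to compound 4 (0.26 log units; within the scatter), and cyano in place of methyl gives a 1.3-fold higher number from compound 2 to compound 4 (0.11 log units; within the scatter). Together with the earlier trifluoromethyl and methyl comparison, these steps set all three groups at this position directly against one another, and none of the three pairs shows a difference beyond the scatter. With the 4-cyanophenyl group held fixed, pyridin-4-yl in place of pyridin-3-yl adds a separate comparison at another part of the molecule and gives a 1.2-fold higher number from compound 1 to compound 4 (0.07 log units; within the scatter), so this change also shows no clear effect. Nothing available explains why these steps are small or shows what the groups do in the cells.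

Cyano, methyl and trifluoromethyl are all small, uncharged groups, so it remains open whether an amine, a carboxylic acid or a longer chain at the same position would move the number beyond the scatter. On these data alone, it is also open whether a plain phenyl in place of pyridin-4-yl would do so, and whether these near-equal results would hold in cells other than those of this assay.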